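From 4-hydroxyphenyl to 6-bromopyridin-2-yl on the chain carbon

The source may report more compounds than this note shows. Statements on the series, on what has been measured and on what is new or still open speak of the compounds shown alone.

In an ADME assay on A549 cells (Homo sapiens) for cytotoxicity, read by resazurin assay, with a stated time of 48 h (on this read-out lower numbers stand for higher toxicity in this test and higher numbers for lower toxicity in this test), compound 3 `O=C(Nc1ccc(NCc2ccc(O)cc2)cc1Cl)c1cc(Cl)ccc1O` gives 116000 nM, within the scatter of compound 2 `O=C(Nc1ccc(NCc2ccc(C(F)(F)F)cc2)cc1Cl)c1cc(Cl)ccc1O` at 62700 nM, while compound 1 `O=C(Nc1ccc(NCC2CC2)cc1Cl)c1cc(Cl)ccc1O` gives 14400 nM. Compound 4 `O=C(Nc1ccc(NCc2cccc(Br)n2)cc1Cl)c1cc(Cl)ccc1O` carries 6-bromopyridin-2-yl in place of 4-hydroxyphenyl on a saturated chain carbon bound to a nitrogen on an aromatic ring. Among the measured compounds shown here, three steps bear on this change. Replacing cyclopropyl with an aromatic ring gave a 4.4-fold higher number from compound 1 to compound 2 (0.64 log units; beyond the scatter) and an 8.1-fold higher number from compound 1 to compound 3 (0.91 log units; beyond the scatter), both modest, whereas exchanging the group on the aromatic ring gave only a 1.9-fold higher number from compound 2 to compound 3 (0.27 log units; within the scatter). Compound 4 keeps an aromatic ring at this place, so the expected step in this assay leans lower but stays within the scatter: a 1.9-fold lower number from compound 3 to compound 4 (0.29 log units; within the scatter). The estimate for compound 4 is 60000 nM, with an expected range of 20000 nM to 130000 nM.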

Compound 4, half-maximal cytotoxic concentration: 92300 nM
Compound 4: the middle estimate sits 1.5-fold (0.19 log units) below what was measured, within the range that was stated.
By their numbers in this assay, from the lowest: compound 1; then compounds 2, 4 and 3 (each within the scatter of the next).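

In this assay, the change to 6-bromopyridin-2-yl stays within the scatter, with a 1.3-fold lower number from compound 3 to compound 4 (0.10 log units; within the scatter) and a 1.5-fold higher number from compound 2 to compound 4 (0.17 log units; within the scatter), so a ring with one hetero atom and no hydrogen-bond donor reads here like the two carbon-only aromatic rings. Against cyclopropyl the step lies beyond the scatter, a 6.4-fold higher number from compound 1 to compound 4 (0.81 log units; beyond the scatter), so all three aromatic groups shown stand apart from compound 1. Nothing given here explains these steps.

Still open, from the compounds shown here alone, is how an amine or a carboxylic acid at this place would read, and whether a longer chain would read like cyclopropyl.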